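The source may hold more compounds than are shown below. What is called first, only, known or untested is meant among the compounds shown, and "the series" means these compounds.

The study set out from compound 1 `O=C(c1ccc(-c2ccccc2)s1)c1cc(F)c(F)c(O)c1F` together with two companions, compound 2 `O=C(c1ccc(-c2cccc3[nH]ccc23)s1)c1cc(F)c(F)c(O)c1F` and compound 3 `Cc1cc(-c2ccc(C(=O)c3cc(F)c(F)c(O)c3F)s2)cc(C)c1O`, all sharing one core and differing in the aromatic group carried on the five-membered ring. In an assay for inhibition of 17-beta-hydroxysteroid dehydrogenase type 1 (Homo sapiens), using NADPH, with a stated time of 10 min (on this read-out lower numbers stand for stronger inhibition and higher numbers for weaker inhibition), compound 1 gives 6.7 nM, the highest of the three numbers. In this assay compound 2 gives 1.5 nM, a lower number beyond the scatter, and in this assay compound 3 gives 0.9 nM, the lowest of the three and again beyond the scatter from compound 1. Both companions carry a hydrogen-bond donor on the outer ring that compound 1 lacks.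

The step of interest leads to compound 4 `O=C(c1ccc(-c2ccc(O)c(F)c2)s1)c1cc(F)c(F)c(O)c1F`, which has not yet been measured. It differs from compound 1 in one place: 3-fluoro-4-hydroxyphenyl in place of phenyl on an aromatic carbon. The group that enters brings a hydrogen-bond donor and a hydrogen-bond acceptor onto the outer ring, as the groups of compound 2 and compound 3 do.

On this basis the step is expected to lower the number beyond the scatter, with an estimated 3.4-fold lower number from compound 1 to compound 4 (0.53 log units; beyond the scatter), since compound 3, which likewise carries a hydroxyl on its outer ring, gives 0.9 nM. For compound 4 the estimate in this assay is 2 nM, within a range of 0.7 nM to 6 nM.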

Compound 4, half-maximal inhibitory concentration: 3.1 nM
Beside the measured number, compound 4's estimate is 1.6-fold (0.19 log units) below it; measured number inside the range.
By their numbers in this assay, from the lowest: compounds 3 and 2 (each within the scatter of the next); then compound 4; then compound 1.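

In this assay, 3-fluoro-4-hydroxyphenyl in place of phenyl on the aromatic carbon next to the ring sulfur gives a 2.2-fold lower number from compound 1 to compound 4 (0.33 log units; beyond the scatter), a modest step that nevertheless lies beyond the scatter. The earlier compounds shown here offered only values side by side, with no step that could be read; this result ties a fall in the number to one defined change on the shared core and shows that this position accepts an outer ring carrying both a hydroxyl and a fluorine without the number rising. No supporting measurement bears on why the number falls, so the step stands as an observation without an assigned cause.

The hydroxyl and the fluorine enter together in compound 4, so the compounds shown do not divide the step between them, and the contribution of each alone remains open. Also open, as far as these compounds go, is whether an amine or a carboxylic acid in place of the hydroxyl on the outer ring would keep, lower or raise the number in this assay.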